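The source may hold more compounds than are shown below. What is called first, only, known or untested is meant among the compounds shown, and "the series" means these compounds.

Compound 1 `Cc1ccc(NC2=CC(=O)c3nc4n(c3C2=O)[C@H]2OC[C@@H](O)[C@H]2OC4)cc1C`: 2690 nM
Compound 2 `Cc1ccc(NC2=CC(=O)c3c(nc4n3[C@H]3OC[C@@H](O)[C@H]3OC4)C2=O)cc1`: 6590 nM
Compound 3 `O=C1C=C(N2CCCCC2)C(=O)c2c1nc1n2[C@H]2OC[C@@H](O)[C@H]2OC1`: > 16000 nM

These values come from a functional assay on HeLa cells (Homo sapiens) for inhibition, read by sulforhodamine B assay; on this read-out lower numbers stand for stronger inhibition and higher numbers for weaker inhibition. The entry for compound 3 is a limit of the assay, not a number (the limit of > 16000 nM in this assay, at which 1 of the 3 values shown sits). Of the two numbers, compound 2 has the higher one; its nearest neighbour is compound 1, which sits beyond the scatter below it. Compound 4 `O=C1C(Nc2ccc(I)cc2)=CC(=O)c2c1nc1n2[C@H]2OC[C@@H](O)[C@H]2OC1` has not yet been measured; it differs from compound 2 by iodo in place of methyl on an aromatic carbon. Among the measured compounds shown here, the only measured step, an at least 5.9-fold higher number from compound 1 to compound 3 (0.77 log units; beyond the scatter), replaces the whole anilino group with a saturated ring, a different kind of change from exchanging one substituent for another on the phenyl ring. For the measured compounds named here, no measured step resembles the change to compound 4, so a shift within the scatter, in no particular direction, is expected. Compound 4 is estimated at 5000 nM, between 1500 nM and 16000 nM, an expected step of a 1.3-fold lower number from compound 2 to compound 4 (0.12 log units; within the scatter).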

Compound 4, half-maximal inhibitory concentration: 4010 nM
Compound 4: middle estimate off by 1.2-fold (0.10 log units), on the high side; the range from low to high includes it.
By their numbers in this assay, from the lowest: compounds 1, 4 and 2 (each within the scatter of the next, the first and the last beyond it). At a limit, above all of these: compound 3.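

In this assay, going from 4-methylphenyl to 4-iodophenyl gives a 1.6-fold lower number from compound 2 to compound 4 (0.22 log units; within the scatter), so this place on the phenyl ring accepts iodo in place of methyl without a shift beyond the scatter. Methyl and iodo therefore cannot be told apart by this read-out, at least on this pair of compounds. Nothing measured here explains the step. Still open, from the compounds shown here alone, is whether a different group at this place, such as an amine, a carboxylic acid or a longer chain, would move the number beyond the scatter.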